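Three aryl groups on one ring nitrogen and cell tolerance

A few compounds are considered here, and "the series" means these few. Any claim that something is new, unique, unknown or untested is made for them only; others in the source may bear on it.

Among the measured compounds shown here, compound 1 `CCN1C(=O)N(c2ccc(O)cc2)C(=O)N(c2ccccc2)c2cc(C(F)(F)F)ccc21` is the only member of this small set with a plain number in an ADME assay on C8166 cells (Homo sapiens) for cytotoxicity; a higher number here means that more compound is tolerated, a lower number that less compound is tolerated; in that assay compound 1 gives 35000 nM. Compound 2 `CCN1C(=O)N(c2ccc(C)cc2)C(=O)N(c2ccccc2)c2cc(C(F)(F)F)ccc21` carries a methyl in place of hydroxy on an aromatic carbon. In this assay compound 2 gives only a limit of the assay, > 6500 nM. Compound 3 `CCN1C(=O)N(c2cccc(C(=O)NC)c2)C(=O)N(c2ccccc2)c2cc(C(F)(F)F)ccc21` carries 3-(methylcarbamoyl)phenyl in place of 4-hydroxyphenyl on an amide-type nitrogen in a ring. In this assay compound 3 likewise gives only a limit, > 22000 nM. Accordingly the step that the limit leaves unreadable from compound 1 to compound 2, the step that the limit leaves unreadable from compound 1 to compound 3 and the step that the two limits leave unreadable from compound 2 to compound 3 have no readable size.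

Compound 4 `CCN1C(=O)N(c2cc(C)c(O)c(Cl)c2)C(=O)N(c2ccccc2)c2cc(C(F)(F)F)ccc21` differs from compound 1 in one place: 3-chloro-4-hydroxy-5-methylphenyl in place of 4-hydroxyphenyl on an amide-type nitrogen in a ring. For the measured compounds named here, no measured step with a readable size bears on this change, so nothing in the set points to a shift in either direction beyond the usual scatter. Compound 4 is therefore expected to give about 35000 nM in this assay, between 12000 nM and 100000 nM, which as an estimated step means no change at the digits printed from compound 1 to compound 4 (within the scatter).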

Compound 4, half-maximal cytotoxic concentration: > 10000 nM
Compound 4: only a limit was reported (the forecaster's own chance of this, stated with the estimate: 40%); the middle value is on the limit's open side.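

Compound 4 gives > 10000 nM in this assay and this is only a limit of the assay. Its steps from compound 1, compound 2 and compound 3 therefore cannot be read. The compounds shown leave open whether 3-chloro-4-hydroxy-5-methylphenyl in place of 4-hydroxyphenyl changes how much compound the cells tolerate.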